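Azetidine to pyrrolidine amide in the solubility series

The source may hold more compounds than are shown below. What is called first, only, known or untested is meant among the compounds shown, and "the series" means these compounds.

Values measured so far in a physicochemical assay for solubility, measured as kinetic solubility (on this read-out higher numbers stand for higher solubility and lower numbers for lower solubility), are these:
Compound 1 `Cc1cnc(NC(=O)c2cc(Oc3cnc(C(=O)N(C)C)cn3)c3cc(C)oc3c2)cn1` gives 176000 nM in this read-out
Compound 2 `CCN(C)C(=O)c1cnc(Oc2cc(C(=O)Nc3cnc(C)cn3)cc3oc(C)cc23)cn1` gives 344000 nM in this read-out
Compound 3 `Cc1cnc(NC(=O)c2cc(Oc3cnc(C(=O)N4CCC4)cn3)c3cc(C)oc3c2)cn1` gives 10000 nM in this read-out

Compound 3 holds the lowest of the three numbers, and its gaps to compound 1 and compound 2 both lie beyond the scatter. The next analogue is compound 4 `Cc1cnc(NC(=O)c2cc(Oc3cnc(C(=O)N4CCCC4)cn3)c3cc(C)oc3c2)cn1`, with pyrrolidin-1-yl in place of azetidin-1-yl on a carbonyl carbon. Within the data shown here, no measured compound carries this group, so the guidance is indirect. Two large steps lead to azetidin-1-yl from the open-chain amino groups (an 18-fold lower number from compound 1 to compound 3 (1.25 log units; beyond the scatter)) and (a 34-fold lower number from compound 2 to compound 3 (1.54 log units; beyond the scatter)). Adding a methyl to the chain changes little (a 2.0-fold higher number from compound 1 to compound 2 (0.29 log units; within the scatter)). These steps suggest that the azetidin-1-yl value may not carry over to a different ring, though they cannot show it. A moderate rise is therefore expected in this assay, with the estimated size being a 4.0-fold higher number from compound 3 to compound 4 (0.60 log units; beyond the scatter) on this reasoning. For compound 4 the estimated value is 40000 nM with an expected range from 9000 nM to 180000 nM as a working figure.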

Compound 4, solubility: 4500 nM
For compound 4 the middle estimate is 8.9-fold (0.95 log units) above the measured one, and the stated range ends above it.
By their numbers in this assay, from the lowest: compound 4; then compound 3; then compounds 1 and 2 (each within the scatter of the next).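

The second ring amide settles the question left open by compound 3: on this carbonyl carbon, pyrrolidin-1-yl does not return this assay to the open-chain level, and it gives a modest further fall (a 2.2-fold lower number from compound 3 to compound 4 (0.35 log units; beyond the scatter)). The gaps from the open-chain amides are large on both sides (a 39-fold lower number from compound 1 to compound 4 (1.59 log units; beyond the scatter); a 76-fold lower number from compound 2 to compound 4 (1.88 log units; beyond the scatter)), so compound 4 now holds the lowest number of the four. Among these compounds, then, both ring amides lie beyond the scatter below both open-chain amides, and no compound goes against that split.

As far as these compounds go, whether the trend continues with piperidin-1-yl on the same carbonyl carbon, or changes with morpholin-4-yl, remains open. Nothing available here explains these steps.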